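A few compounds are considered here, and "the series" means these few. Any claim that something is new, unique, unknown or untested is made for them only; others in the source may bear on it.

Measured in an in vivo ADME assay on the whole organism (plasma) for pharmacokinetics, with Rattus norvegicus as the target, at a dose of 50 mg/kg by the oral route; a lower number here means less compound in the circulation, a higher number more compound in the circulation at the dose given:
- compound 1 `Cc1cc(C)c(NC(=O)c2sccc2S(=O)(=O)Nc2onc(C)c2Cl)c(C)c1` gives 81600 nM
- compound 2 `CC(=O)OCc1c(C)cc(C)c(NC(=O)c2sccc2S(=O)(=O)Nc2onc(C)c2Cl)c1C` gives 7420 nM
- compound 3 `Cc1cc(C)c(NS(C)(=O)=O)c(C)c1NC(=O)c1sccc1S(=O)(=O)Nc1onc(C)c1Cl` gives 5250 nM

Compound 3 sits with compound 2 at the low end of this short series, and the two are not separated: a 1.4-fold lower number from compound 2 to compound 3 (0.15 log units; within the scatter). Compound 1 stands well clear of it, with a 16-fold lower number from compound 1 to compound 3 (1.19 log units; beyond the scatter).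

The next step leads to compound 4 `Cc1cc(C)c(NC(=O)c2sccc2S(=O)(=O)Nc2onc(C)c2Cl)c(C)c1C#N`: cyano in place of methanesulfonamido on an aromatic carbon. This puts cyano in place of methanesulfonamido on an aromatic carbon, ortho to two methyl groups and para to a methyl group.

Within the data shown here, three measured steps bear on this. Two are large and replace hydrogen on an aromatic carbon: an 11-fold lower number from compound 1 to compound 2 (1.04 log units; beyond the scatter), alongside a 16-fold lower number from compound 1 to compound 3 (1.19 log units; beyond the scatter) already noted. Among the measured compounds shown here, the third is the only exchange of one such group for another, and it stayed small: a 1.4-fold lower number from compound 2 to compound 3 (0.15 log units; within the scatter). For the measured compounds named here, no measured compound carries cyano, so the read-across is loose.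

Compound 4 keeps a group at this carbon, so a full return to the level of compound 1 is not expected. The entering group is smaller than the one leaving, so a modest rise is expected rather than a fall. The expected change is a 2.3-fold higher number from compound 3 to compound 4 (0.36 log units; beyond the scatter). For compound 4 the estimated value is 12000 nM, with an expected range of 4000 nM to 40000 nM.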

Compound 4, maximal plasma concentration: 37200 nM
Beside the measured number, compound 4's estimate is 3.1-fold (0.49 log units) below it, and the stated range covers the measured number.
By their numbers in this assay, from the lowest: compounds 3 and 2 (each within the scatter of the next); then compound 4; then compound 1.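

In this assay the exchange of one group for another at this carbon is no longer a small matter: there is a 7.1-fold higher number from compound 3 to compound 4 (0.85 log units; beyond the scatter) and a 5.0-fold higher number from compound 2 to compound 4 (0.70 log units; beyond the scatter) when cyano enters, whereas the exchange of acetoxymethyl for methanesulfonamido gave only a 1.4-fold lower number from compound 2 to compound 3 (0.15 log units; within the scatter) and left those two compounds unseparated. Carrying a group at this carbon therefore does not by itself fix the number at the level of compound 2 and compound 3, and cyano gives an intermediate place, still with a 2.2-fold lower number from compound 1 to compound 4 (0.34 log units; beyond the scatter) and so still distinct from the hydrogen of compound 1. Nothing available explains why these three groups fall where they do.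

Whether the order follows the heavy-atom count of the entering group or something else cannot be settled from three groups, so a fluorine, a methoxy group, an amine or a carboxylic acid at this carbon could fall anywhere in the range. Only the maximal plasma concentration is shown, which leaves open whether total exposure over time and clearance would rank these compounds in the same order.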